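This account rests on a few compounds, and the source may have more. Where it says the series, first, only, none or still open, it means among the compounds named here.

Measured so far in an ADME assay on MT2 cells (Homo sapiens) for cytotoxicity, read by XTT assay, with a stated time of 4 days; a higher number here means that more compound is tolerated, a lower number that less compound is tolerated:
Compound 1, `Cc1ccc(-c2c3c(nc(C)c2C(OC(C)(C)C)C(=O)O)CCN(S(C)(=O)=O)C3)cc1`, gives > 40000 nM; this is a limit of the assay, not a number.
Compound 2, `Cc1ccc(-c2c3c(nc(C)c2C(OC(C)(C)C)C(=O)O)CCN(C)C3)cc1`, gives > 40000 nM; again a limit, not a number.
Compound 3, `Cc1ccc(-c2c3c(nc(C)c2[C@H](OC(C)(C)C)C(=O)O)CCN(C/C=C/c2ccccc2)C3)cc1`, gives > 40000 nM; again a limit, not a number.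

Compound 2 therefore stands only at a limit, like every other value shown (the limit of > 40000 nM in this assay, at which 3 of the 3 values shown sit). Among the compounds with values here, the one step between measured compounds, a step that the two limits leave unreadable from compound 1 to compound 2, is unreadable because the limit of > 40000 nM in this assay, at which 3 of the 3 values shown sit, holds at both of its ends.

Compound 4, `CCCCCN1CCc2nc(C)c(C(OC(C)(C)C)C(=O)O)c(-c3ccc(C)cc3)c2C1`, differs from compound 2 by butyl in place of hydrogen on a saturated chain carbon bound to an amine nitrogen in a ring. Within the data shown here, no measured step gives a readable size, so the only guide is that all three values sit at the limit (the limit of > 40000 nM in this assay, at which 3 of the 3 values shown sit). No change beyond the scatter is expected in this assay. Compound 4 is expected at 60000 nM, within 30000 nM to 150000 nM, most likely reported again only as a limit. The expected step is a step that the limit leaves unreadable from compound 2 to compound 4.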

Compound 4, half-maximal cytotoxic concentration: > 40000 nM
Compound 4 was reported as a limit; the forecaster's own chance of this, stated with the estimate: 85%; the middle value is on the limit's open side.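

The steps from compound 2 and from compound 1 to compound 4 cannot be read, since both ends of each are limits: the limit of > 40000 nM in this assay, at which 4 of the 4 values shown sit.
The compounds shown leave open whether changing the group on the ring amine nitrogen shifts the half-maximal cytotoxic concentration at all in this assay.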